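Chain extension on the sulfanyl arm of compound 3

This account rests on a few compounds, and the source may have more. Where it says the series, first, only, none or still open, it means among the compounds named here.

Compound 3 `Cc1cc(N2CC[C@@H](C)[C@@H](N(C)c3ncnc4[nH]ccc34)C2)n2nc(SCCc3ccccc3)nc2n1` carries a phenethylsulfanyl group on an aromatic carbon of the shared core. In a functional assay on BGC-823 cells (Homo sapiens) for inhibition, read by MTT assay, with a stated time of 72 h (a higher number here means a weaker inhibitor, a lower number a stronger inhibitor), compound 3 gives 28000 nM, the lowest of the three numbers recorded so far. Compound 1 `Cc1cc(N2CC[C@@H](C)[C@@H](N(C)c3ncnc4[nH]ccc34)C2)n2ncnc2n1`, which bears hydrogen at that aromatic carbon, gives 67400 nM in this assay. Compound 2 `C=CCSc1nc2nc(C)cc(N3CC[C@@H](C)[C@@H](N(C)c4ncnc5[nH]ccc45)C3)n2n1`, with allylsulfanyl in the same place, gives 40900 nM. The step of a 2.4-fold lower number from compound 1 to compound 3 (0.38 log units; beyond the scatter) is modest, whereas a 1.5-fold lower number from compound 2 to compound 3 (0.16 log units; within the scatter) and a 1.6-fold lower number from compound 1 to compound 2 (0.22 log units; within the scatter) both stay inside the scatter, so compound 3 and compound 2 cannot be set apart on these numbers.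

Compound 4 `Cc1cc(N2CC[C@@H](C)[C@@H](N(C)c3ncnc4[nH]ccc34)C2)n2nc(SCCCc3ccccc3)nc2n1` has not yet been measured. It differs from compound 3 by benzyl in place of phenyl on a saturated chain carbon, two bonds along the chain from a sulfur. The measured step that bears most directly on this is a 1.5-fold lower number from compound 2 to compound 3 (0.16 log units; within the scatter), a change on the same saturated chain bound to sulfur that produced no shift beyond the scatter. The step of a 2.4-fold lower number from compound 1 to compound 3 (0.38 log units; beyond the scatter) shows that installing the whole phenethylsulfanyl arm brought only a modest gain. Adding one more carbon to that chain is therefore expected to leave this assay essentially unchanged, with at most a small move downward. For compound 4 the expected step is a 1.1-fold lower number from compound 3 to compound 4 (0.05 log units; within the scatter). For compound 4 the estimate in this assay is 25000 nM, with a range from 12000 nM to 50000 nM.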

Compound 4, half-maximal inhibitory concentration: > 100000 nM
Compound 4 gave a limit, no number; the forecaster's own chance of this, stated with the estimate: 5%; middle value at least 4.0-fold (0.60 log units) from the limit.
By their numbers in this assay, from the lowest: compounds 3, 2 and 1 (each within the scatter of the next, the first and the last beyond it). At a limit, above all of these: compound 4.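

Compound 4 stands at a limit of this assay, not at a number: the limit of > 100000 nM in this assay, at which 1 of the 4 values shown sits. Within the data shown here, one more carbon on the saturated chain, two bonds along from the sulfur, gives the first steps that go upward beyond the scatter, an at least 3.5-fold higher number from compound 3 to compound 4 (0.55 log units; beyond the scatter) and an at least 2.4-fold higher number from compound 2 to compound 4 (0.38 log units; beyond the scatter), so this arm does not tolerate every extension, and phenethylsulfanyl to (3-phenylpropyl)sulfanyl is not a neutral change. Against the core without a sulfanyl arm the reading is weaker, an at least 1.4-fold higher number from compound 1 to compound 4 (0.17 log units; that floor lies within the scatter), so the modest gain seen with the phenethylsulfanyl arm is gone at this length, but compound 4 cannot be placed beyond the scatter from the hydrogen compound.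

On these data alone, the true size of the loss stays unknown, as does whether it follows from chain length alone or from chain length together with the phenyl ring. A benzylsulfanyl arm, a longer chain without the phenyl ring, or a chain of the same length ending in an amine or a carboxylic acid would separate these readings.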